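The source may hold more compounds than are shown below. What is called first, only, known or untested is meant among the compounds shown, and "the series" means these compounds.

Three compounds have been measured in an assay on HEK293 cells for displacement of a labelled ligand from metabotropic glutamate receptor 5 (Homo sapiens), with a stated time of 2 h; on this read-out lower numbers stand for stronger inhibition and higher numbers for weaker inhibition:

compound 1 `Cc1cccc(C#Cc2ccc3c(n2)CCN(C2CCCC2)C3=O)c1` gives 670 nM;
compound 2 `Cc1ccc(C#Cc2ccc3c(n2)CCN(C2CCCC2)C3=O)cc1` gives > 32000 nM, which is a limit of the assay and not a number;
compound 3 `Cc1cccc(C#Cc2ccc3c(n2)CCN(C2CCCCC2)C3=O)c1` gives 3210 nM.

Compound 4 `Cc1ccc(C#Cc2ccc3c(n2)CCN(C2CCCCC2)C3=O)cc1` has not yet been measured. It differs from compound 3 by 4-methylphenyl in place of 3-methylphenyl on a triple-bonded carbon. The same change, (4-methylphenyl in place of 3-methylphenyl on a triple-bonded carbon), turns compound 1 into compound 2, with the step of an at least 47-fold higher number from compound 1 to compound 2 (1.67 log units; beyond the scatter), a step that ends at a limit (the limit of > 32000 nM in this assay, at which 1 of the 3 values shown sits). The cores of compound 1 and compound 3 differ by cyclohexyl in place of cyclopentyl on an amide-type nitrogen in a ring, with the step of a 4.8-fold higher number from compound 1 to compound 3 (0.68 log units; beyond the scatter). A similarly large step is expected for compound 4, since its change is the same as the earlier one. The expected step is a 25-fold higher number from compound 3 to compound 4 (1.40 log units; beyond the scatter), resting on an at least 47-fold higher number from compound 1 to compound 2 (1.67 log units; beyond the scatter). Compound 4 is therefore expected to give about 80000 nM, most likely between 20000 nM and 400000 nM.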

Compound 4, inhibition constant: 27200 nM
The estimate for compound 4 lay 2.9-fold (0.47 log units) above the measured number; the measured number falls inside the stated range.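

In this assay, 4-methylphenyl in place of 3-methylphenyl on a triple-bonded carbon again gives weaker inhibition, with an 8.5-fold higher number from compound 3 to compound 4 (0.93 log units; beyond the scatter). The direction of the change therefore carries from one core to the other, but its size does not: the same change on two cores in this assay, an at least 47-fold higher number (1.67 log units; beyond the scatter) from compound 1 to compound 2 and an 8.5-fold higher number (0.93 log units; beyond the scatter) from compound 3 to compound 4, at least 5.6-fold (0.75 log units) apart, beyond the scatter of two such steps. From the compounds shown here alone, compound 2 gives > 32000 nM, which is a limit of the assay and not a number, so the full size of the step on the cyclopentyl core remains unknown. Cyclohexyl in place of cyclopentyl on an amide-type nitrogen in a ring comes with an at least 1.1-fold lower number from compound 2 to compound 4 (0.07 log units; that floor lies within the scatter), a step that starts from that limit.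

Within the data shown here, with only two cores, this is not a general rule. Going by these compounds, it remains open how the change behaves with a cyclobutyl group or a longer chain on the ring nitrogen, and whether a methoxy group or a chlorine atom would follow the same pattern as the methyl group.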